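Chloro to fluoro on the pyridine of compound 3

The source may report more compounds than this note shows. Statements on the series, on what has been measured and on what is new or still open speak of the compounds shown alone.

Compound 1 `O=C1C(=O)N(Cc2ccc(-c3ccccc3)cc2)c2ccc(OC(F)(F)F)cc21` gives 2700 nM in a functional assay on CHO cells for agonist activity at muscarinic acetylcholine receptor M5 (Homo sapiens), read by calcium flux; a higher number here means that more compound is needed for the effect, a lower number that less compound is needed; compound 2 `O=C1C(=O)N(Cc2ccc(-c3ccsc3)cc2)c2ccc(OC(F)(F)F)cc21` gives 2800 nM and compound 3 `O=C1C(=O)N(Cc2ccc(-c3ccc(Cl)nc3)cc2)c2ccc(OC(F)(F)F)cc21` gives 4800 nM. Compound 3 sits at the top of the three numbers, but only by a 1.8-fold higher number from compound 1 to compound 3 (0.25 log units; within the scatter) and a 1.7-fold higher number from compound 2 to compound 3 (0.23 log units; within the scatter), so the three sit together within the scatter. Compound 4 `O=C1C(=O)N(Cc2ccc(-c3ccc(F)nc3)cc2)c2ccc(OC(F)(F)F)cc21` carries fluoro in place of chloro on an aromatic carbon. Going by the values given here, no measured step swaps one halogen for another; the three aryl exchanges, including a 1.0-fold higher number from compound 1 to compound 2 (0.02 log units; within the scatter), all stayed within the scatter, which suggests the shared core tolerates small changes at this distal ring. The expected step is about a 1.1-fold lower number from compound 3 to compound 4 (0.03 log units; within the scatter) and would not go beyond the scatter. Compound 4 is estimated at 4500 nM, in the range 2000 nM to 10000 nM.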

Compound 4, half-maximal effective concentration: 3600 nM
For compound 4 the middle estimate is 1.3-fold (0.10 log units) above the measured one; measured number inside the range.
By their numbers in this assay, from the lowest: compounds 1, 2, 4 and 3 (each within the scatter of the next).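

In this assay, going by these compounds alone, the first halogen exchange at this carbon next to the ring nitrogen stays within the scatter (a 1.3-fold lower number from compound 3 to compound 4 (0.12 log units; within the scatter)). The 6-fluoropyridin-3-yl group also stays within the scatter of the other two distal rings (a 1.3-fold higher number from compound 2 to compound 4 (0.11 log units; within the scatter); a 1.3-fold higher number from compound 1 to compound 4 (0.12 log units; within the scatter)), so all four groups shown at this position give numbers that cannot be told apart. Nothing available explains this insensitivity. Still open, as far as these compounds go, is whether an amine, a carboxylic acid or a longer chain in place of the halogen would move the number beyond the scatter.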